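A Linker Change on Compound 3, Before the Measurement

The source may hold more compounds than are shown below. What is called first, only, known or untested is meant among the compounds shown, and "the series" means these compounds.

Measured compounds:
compound 1 `O=C(Nc1cccc(-n2cc(-c3ccncc3)c(-c3cc(O)cc(Cl)c3)n2)c1)Nc1ccc(Cl)c(C(F)(F)F)c1` 93%
compound 2 `O=C(Nc1cccc(-n2cc(-c3ccncc3)c(-c3cc(O)cc(Cl)c3)n2)c1)Nc1ccc(Cl)c(Cl)c1` 95%
compound 3 `COc1cc(Cl)cc(-c2nn(-c3cccc(NC(=O)Nc4ccc(Cl)c(C(F)(F)F)c4)c3)cc2-c2ccncc2)c1` 57%

In a functional assay on ACHN cells (Homo sapiens) for inhibition, read by sulforhodamine B assay, with a stated time of 48 h, tested at 0.1 uM (a higher number here means a weaker effect of the compound at the concentration tested, a lower number a stronger effect), compound 3 gives the lowest of the three numbers. Its nearest neighbour is compound 1, and the step of a number 36 percentage points lower from compound 1 to compound 3 (beyond the scatter) is large; the only structural difference between them is methyl in place of hydrogen on an oxygen on an aromatic ring. The other measured step, a number 2 percentage points higher from compound 1 to compound 2 (within the scatter), is small and lies within the scatter.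

Compound 4 `COc1cc(Cl)cc(-c2nn(-c3cccc(NC(=O)c4cccc(C(F)(F)F)c4)c3)cc2-c2ccncc2)c1` is not yet measured. It differs from compound 3 at the carbonyl carbon: 3-(trifluoromethyl)phenyl in place of (4-chloro-3-(trifluoromethyl)phenyl)amino on a carbonyl carbon. Neither measured step touches this part of the molecule. The step from compound 1 to compound 2 shows that swapping one group on the far ring changed little, but here a larger piece is removed, including the hydrogen-bond donor counted above, so that step is only a weak guide. For the measured compounds named here, there is no measured step for a change of this kind, and the expectation is therefore uncertain.

Compound 4 is expected to give a higher number than compound 3, the estimated step being a number 21 percentage points higher from compound 3 to compound 4 (beyond the scatter). The estimate for compound 4 is 78%, with a range from 52% to 98%.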

Compound 4, a percentage reported as activity, at one concentration (the size of the read-out at that concentration, not a potency): 98%
Estimate against measurement, compound 4: 20 percentage points below, and the stated range covers the measured number.
By their numbers in this assay, from the lowest: compound 3; then compounds 1, 2 and 4 (each within the scatter of the next).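

In this assay, the step of a number 41 percentage points higher from compound 3 to compound 4 (beyond the scatter) shows that the effect at this concentration depends on the group on the carbonyl carbon, and not only on the methyl on the oxygen at the other end of the molecule. The earlier step from trifluoromethyl to chloro on the far ring made no difference beyond the scatter, whereas this larger change, which removes the amino nitrogen with its hydrogen-bond donor along with the chlorine, does. Nothing measured here explains the loss of effect, and no supporting data on its cause are available.

The compounds shown leave open which part of the change matters, since the nitrogen and the chlorine leave together: (3-(trifluoromethyl)phenyl)amino on the carbonyl carbon would keep the nitrogen without the chlorine, and 4-chloro-3-(trifluoromethyl)phenyl would keep the chlorine without the nitrogen. They also leave open whether the aromatic ring is needed at all at this place, which a simple alkylamine such as cyclohexylamino on the carbonyl carbon would begin to test.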